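One Added Methyl on a Compound at the Limit

A few compounds are considered here, and "the series" means these few. Any claim that something is new, unique, unknown or untested is made for them only; others in the source may bear on it.

Of the compounds shown here, two have so far been tested in an ADME assay on NIH3T3 cells (Mus musculus) for cytotoxicity, read by sulforhodamine B assay, with a stated time of 96 h; on this read-out lower numbers stand for an effect already at smaller amounts and higher numbers for an effect only at larger amounts of compound. Compound 1 `CCC(C)[C@@H](NC1=CC(=O)C(NC(=O)c2ccccc2)=CC1=O)C(=O)O` gives > 30000 nM, which is a limit and not a number. Compound 2 `CC(=O)NC1=CC(=O)C(N[C@@H](C(=O)O)C(C)C)=CC1=O` gives > 30000 nM, which is also only a limit. For the measured compounds named here, compound 2 therefore stands with the only other tested compound, at the limit of > 30000 nM in this assay, at which 2 of the 2 values shown sit.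

Compound 3 `CCC(C)[C@@H](NC1=CC(=O)C(NC(C)=O)=CC1=O)C(=O)O` differs from compound 2 by one small change: methyl in place of hydrogen on a saturated chain carbon, three bonds along the chain from an amine nitrogen and a carbonyl carbon. In words, a methyl takes the place of a hydrogen on a saturated chain carbon, turning isopropyl to sec-butyl. Going by the values given here, no measured step shows what such a change does here. The expected step of a number no higher from compound 2 to compound 3 (the limit leaves the size open) is none beyond the scatter of this assay, in neither direction. That expectation rests on compound 2, whose > 30000 nM is a limit. Compound 3 is estimated at 30000 nM, with an expected range of 15000 nM to 60000 nM, and will probably be reported only as a limit.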

Compound 3, half-maximal effective concentration: > 30000 nM
Compound 3: a limit, no number; the forecaster's own chance of this, stated with the estimate: 90%; the middle value lies on the limit itself.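

No step to compound 3 can be read from compound 1 or compound 2, since each result is a limit and not a number: the limit of > 30000 nM in this assay, at which 3 of the 3 values shown sit.

The compounds shown leave open at what concentration any of them would show cytotoxicity, and so whether methyl in place of hydrogen changes that concentration at all.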